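Three Inactive Compounds and a Saturated Ring Change

This account rests on a few compounds, and the source may have more. Where it says the series, first, only, none or still open, it means among the compounds named here.

Compound 1 `c1ccc2c(c1)CN[C@@H](CN(CCCCN(Cc1ccncc1)Cc1ccncc1)[C@H]1CCCc3cccnc31)C2` gives > 30000 nM in a functional assay on cells for agonist activity at C-X-C chemokine receptor type 4 (Homo sapiens), read by fluorescence and calcium flux, with a stated time of 90 s (on this read-out higher numbers stand for an effect only at larger amounts of compound and lower numbers for an effect already at smaller amounts), which is a limit of the assay and not a number.
Compound 2 `c1ccc(CN(CCCCN(C[C@H]2Cc3ccccc3CN2)[C@H]2CCCc3cccnc32)Cc2ccccc2)cc1` gives > 30000 nM in this assay , again a limit.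
Compound 3 `c1ccc2c(c1)CN[C@@H](CN(CCCCNCC1CCCCC1)[C@H]1CCCc3cccnc31)C2` gives > 30000 nM in this assay , once more a limit.

Compound 3 therefore stands at the limit, together with every other value shown (the limit of > 30000 nM in this assay, at which 3 of the 3 values shown sit). No pair among the measured compounds differs in one place, so no measured step is available, and nothing shown separates compound 3 from compound 1 or compound 2.

Compound 4 `CC1(C)CCC(NCCCCN(C[C@H]2Cc3ccccc3CN2)[C@H]2CCCc3cccnc32)CC1` differs from compound 3 in a single place: 4,4-dimethylcyclohexyl in place of cyclohexylmethyl on an amine nitrogen. The change sits on an amine nitrogen whose other neighbour is a saturated chain carbon, and both the leaving and the entering group are a six-membered non-aromatic ring of carbon only.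

On the numbers shown, the step that the limit leaves unreadable from compound 3 to compound 4 is expected to be none beyond the scatter. Compound 4 is estimated at 40000 nM, with a range from 15000 nM to 100000 nM, and most likely this assay reports again only a limit.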

Compound 4, half-maximal effective concentration: > 30000 nM
Compound 4: a limit, no number; the forecaster's own chance of this, stated with the estimate: 85%; the middle value does not contradict the limit.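

In this assay compound 4 gives > 30000 nM, which is a limit and not a number. Going by these compounds alone, compound 3 also sits at a limit, so no step between compound 3 and compound 4 can be read. The compounds shown leave open which change, if any, would give a readable value: the limit of > 30000 nM in this assay, at which 4 of the 4 values shown sit.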